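Ethyl for methyl on the core of compound 3

A few compounds are considered here, and "the series" means these few. Any claim that something is new, unique, unknown or untested is made for them only; others in the source may bear on it.

Measured so far:
compound 1 `CCc1ccc2[nH]c(-c3ccc(OC)cc3)c(C3=C(Br)C(=O)NC3=O)c2c1` 3.23
compound 2 `CCCCCCOc1ccc2[nH]c(-c3cccc(OC)c3)c(C3=C(Br)C(=O)NC3=O)c2c1` 3.92
compound 3 `COc1cccc(-c2[nH]c3ccc(C)cc3c2C2=C(Br)C(=O)NC2=O)c1` 3.12

In a physicochemical assay for lipophilicity (on this read-out higher numbers stand for higher lipophilicity and lower numbers for lower lipophilicity), compound 3 gives 3.12, the lowest of the three numbers. For the measured compounds named here, compound 1 gives 3.23, which sits within the scatter of compound 3; compound 2 gives 3.92, and the step of a number 0.80 log units lower from compound 2 to compound 3 (beyond the scatter) is the only single-point change measured and lies beyond the scatter.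

Compound 4 `CCc1ccc2[nH]c(-c3cccc(OC)c3)c(C3=C(Br)C(=O)NC3=O)c2c1` is not yet measured. It differs from compound 3 by methyl in place of hydrogen on a saturated chain carbon bound to an aromatic carbon. Going by the values given here, no measured pair shows exactly this change. The pair compound 2 and compound 3 bears on it only loosely, as a removal of chain carbons from the core, and that step was modest. The present change adds back a single carbon, so a step smaller than that one is expected, in the upward direction, close to or just beyond the scatter. Among the compounds with values here, compound 1 and compound 3 differ in two places at once, so their values show only that an ethyl-bearing core and a methyl-bearing core can sit near each other.

For compound 4 the expected step is a number 0.38 log units higher from compound 3 to compound 4 (beyond the scatter). Compound 4 is therefore estimated at 3.5, with a range from 3.2 to 3.9.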

Compound 4, partition coefficient: 3.35
Beside the measured number, compound 4's estimate is 0.15 log units above it; measured number inside the range.
By their numbers in this assay, from the lowest: compounds 3, 1 and 4 (each within the scatter of the next); then compound 2.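

In this assay, the exchange of methyl for ethyl on the core gives a number 0.23 log units higher from compound 3 to compound 4 (within the scatter), so this one-carbon extension at the saturated chain carbon bound to an aromatic carbon cannot be told from the scatter. The pair also gives the first single-place readings against compound 4: ethyl in place of hexyloxy gives a number 0.57 log units lower from compound 2 to compound 4 (beyond the scatter), beyond the scatter and modest like a number 0.80 log units lower from compound 2 to compound 3 (beyond the scatter), while 3-methoxyphenyl in place of 4-methoxyphenyl gives a number 0.12 log units higher from compound 1 to compound 4 (within the scatter), so moving the methoxy group leaves no step beyond the scatter on the ethyl-bearing core. No supporting evidence is available to explain any of these steps.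

Hexyloxy differs from ethyl in both chain length and the oxygen joining it to the core, so a hexyl or butyl chain at this aromatic carbon would be needed to separate those two features. The compounds shown also leave open how this assay responds on this core to an amine or a carboxylic acid at the end of the chain, since every group here at that aromatic carbon is an uncharged alkyl or alkoxy group.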